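Swapping a small ring for a larger aromatic one at the sulfur

This account rests on a few compounds, and the source may have more. Where it says the series, first, only, none or still open, it means among the compounds named here.

Compound 1, with the structure `Cc1cc(N2CC[C@@H](C)[C@@H](N(C)c3ncnc4[nH]ccc34)C2)n2nc(SCC3CC3)nc2n1`, carries a cyclopropyl group on a saturated chain carbon bound to a sulfur. In a functional assay on BGC-823 cells (Homo sapiens) for inhibition, read by MTT assay, with a stated time of 72 h (a lower number here means a stronger inhibitor, a higher number a weaker inhibitor), compound 1 gives 36500 nM, the highest of the two numbers recorded here, which marks it as the weaker of the two measured inhibitors. Its nearest neighbour is compound 2, `Cc1cc(N2CC[C@@H](C)[C@@H](N(C)c3ncnc4[nH]ccc34)C2)n2nc(SCc3cc(Cl)ccc3Cl)nc2n1`, which in this assay gives 18900 nM. For the measured compounds named here, the single step between them, 2,5-dichlorophenyl in place of cyclopropyl on a saturated chain carbon bound to a sulfur, reads a 1.9-fold lower number from compound 1 to compound 2 (0.29 log units; within the scatter), a change too small to count as a real difference.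

Compound 3, `Cc1cc(N2CC[C@@H](C)[C@@H](N(C)c3ncnc4[nH]ccc34)C2)n2nc(SCc3csc4ccc(Cl)cc34)nc2n1`, has not yet been measured. It differs from compound 1 as follows: 5-chloro-1-benzothiophen-3-yl in place of cyclopropyl on a saturated chain carbon bound to a sulfur. Going by the values given here, the only step that bears on this change is the one from compound 1 to compound 2, where another flat aromatic ring took the place of the same cyclopropyl and moved the number only a little. A similar outcome is expected here, so compound 3 is estimated to shift by a 1.9-fold lower number from compound 1 to compound 3 (0.28 log units; within the scatter) in this assay, a step that may not exceed the scatter. Compound 3 is therefore expected to give about 19000 nM, with a plausible range from 6000 nM to 55000 nM.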

Compound 3, half-maximal inhibitory concentration: > 100000 nM
Compound 3: a limit, no number; the forecaster's own chance of this, stated with the estimate: 5%; middle value at least 5.2-fold (0.72 log units) away from the limit.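

What the larger ring changes at the sulfur

Compound 3 stands at a limit of this assay, not at a number: the limit of > 100000 nM in this assay, at which 1 of the 3 values shown sits.

Even so, the limit shows that this place, on a saturated chain carbon bound to a sulfur, does not treat all aromatic groups alike, which compounds 1 and 2 alone could not show: replacing cyclopropyl with 5-chloro-1-benzothiophen-3-yl gives an at least 2.7-fold higher number from compound 1 to compound 3 (0.43 log units; beyond the scatter), and replacing 2,5-dichlorophenyl with the same group gives an at least 5.2-fold higher number from compound 2 to compound 3 (0.72 log units; beyond the scatter). The earlier step from cyclopropyl to 2,5-dichlorophenyl stayed within the scatter, so the mere presence of an aromatic ring at this place does not predict the result in these three compounds.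

These compounds leave open whether the change is tied to the second ring, the ring sulfur or the chlorine of 5-chloro-1-benzothiophen-3-yl, and how far the true value of compound 3 lies past its limit. They also leave open how a plain phenyl, an amine, a carboxylic acid or a longer chain at this place would read in this assay.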